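Adding a tert-butyl group to the phenyl of compound 3

A few compounds are considered here, and "the series" means these few. Any claim that something is new, unique, unknown or untested is made for them only; others in the source may bear on it.

Of the compounds shown here, three sharing a benzyloxy-substituted core have been tested in a functional assay on MDA-MB-231 cells (Homo sapiens) for antiproliferative activity, read by MTT assay, with a stated time of 24 h; on this read-out lower numbers stand for stronger inhibition and higher numbers for weaker inhibition. Compound 1 `O=C1NC(O)(CCn2cc(C3=CCCCC3)nn2)C(OCc2ccccc2)=C1OCc1ccccc1` gives 13100 nM, compound 3 `O=C1NC(O)(CCn2cc(-c3ccccc3)nn2)C(OCc2ccccc2)=C1OCc1ccccc1` gives 21100 nM, and compound 2 `CC(C)(C)c1ccc(-c2cn(C/C=C3\OC(=O)C(OCc4ccccc4)=C3OCc3ccccc3)nn2)cc1`, built on a different core, gives 51200 nM. Among these, compound 3 stands second highest; it sits closest to compound 1 and furthest from compound 2.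

Compound 4 `CC(C)(C)c1ccc(-c2cn(CCC3(O)NC(=O)C(OCc4ccccc4)=C3OCc3ccccc3)nn2)cc1` differs from compound 3 in one place: tert-butyl in place of hydrogen on an aromatic carbon. Within the data shown here, only one measured step concerns this part of the molecule, and it is a different change: a 1.6-fold higher number from compound 1 to compound 3 (0.21 log units; within the scatter), which lies within the scatter. Among the measured compounds shown here, no measured pair shows a tert-butyl added to an otherwise identical compound, so the effect of this group on this core is unknown; compound 2 carries the same tert-butylphenyl but on another core, and its value can only be compared loosely with compound 3.

Given this, no step beyond the scatter is expected in this assay, with a slight lean toward a higher number: the estimate for compound 4 is 26000 nM, between 11000 nM and 62000 nM, corresponding to an expected 1.2-fold higher number from compound 3 to compound 4 (0.09 log units; within the scatter).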

Compound 4, half-maximal inhibitory concentration: > 100000 nM
Compound 4 was reported as a limit; the forecaster's own chance of this, stated with the estimate: 5%; middle value at least 3.8-fold (0.58 log units) from the limit.
By their numbers in this assay, from the lowest: compounds 1 and 3 (each within the scatter of the next); then compound 2. At a limit, above all of these: compound 4.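

In this assay, among these compounds, the only earlier change at this position, a 1.6-fold higher number from compound 1 to compound 3 (0.21 log units; within the scatter), stayed within the scatter, which gave no sign that the group here matters much. Placing a tert-butyl on the phenyl ring gives an at least 4.7-fold higher number from compound 3 to compound 4 (0.67 log units; beyond the scatter), and replacing the cyclohex-1-en-1-yl group with 4-(tert-butyl)phenyl gives an at least 7.6-fold higher number from compound 1 to compound 4 (0.88 log units; beyond the scatter), so this position does respond to a change, and both steps lie beyond the scatter. Compound 4 is reported only as a limit, which makes both steps minimum sizes: the limit of > 100000 nM in this assay, at which 1 of the 4 values shown sits.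

The compounds shown leave open whether a methyl group or a fluorine atom on the same carbon would already raise the number, or whether the effect is confined to tert-butyl. From the compounds shown here alone, how an amine or a carboxylic acid at this place would behave also remains open.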